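A Pyridyl Variant Weighed Against Three Aryl Analogues

The compounds below may be only part of what the source reports. "The series", "measured", "known", "first", "only" and "open" are said of these compounds alone.

In an assay (Rattus norvegicus) for inhibition of Fatty-acid amide hydrolase 1 (Homo sapiens) (a higher number here means a weaker inhibitor, a lower number a stronger inhibitor), compound 3 `N#Cc1ccc(-c2cnc(C(=O)CCCCCCc3ccccc3)o2)cc1` gives 40 nM, the second highest of the three numbers measured. Compound 1 `N#Cc1cccc(-c2cnc(C(=O)CCCCCCc3ccccc3)o2)c1` gives 15 nM, and compound 2 `COc1ccc(-c2cnc(C(=O)CCCCCCc3ccccc3)o2)cc1` gives 100 nM. For the measured compounds named here, the steps that bear on the next change are a 2.7-fold higher number from compound 1 to compound 3 (0.43 log units; beyond the scatter) and a 2.5-fold lower number from compound 2 to compound 3 (0.40 log units; beyond the scatter). Compound 4 `Cc1ccc(-c2cnc(C(=O)CCCCCCc3ccccc3)o2)nc1` differs from compound 3 by 5-methylpyridin-2-yl in place of 4-cyanophenyl on an aromatic carbon. The step from compound 2 to compound 3 speaks most directly to this: it shows what the cyano group is worth against a methoxy group on an aromatic carbon, and the change to compound 4 likewise removes the cyano group. A modest move toward a higher number in this assay is therefore expected, a 2.0-fold higher number from compound 3 to compound 4 (0.30 log units; within the scatter). Compound 4 is accordingly estimated at 80 nM, within a range of 25 nM to 250 nM.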

Compound 4, inhibition constant: 2.8 nM
Estimate against measurement, compound 4: 29-fold (1.46 log units) above; measured number outside the range, below it.
By their numbers in this assay, from the lowest: compound 4; then compound 1; then compound 3; then compound 2.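

In this assay, the position next to the ring oxygen gives a 14-fold lower number from compound 3 to compound 4 (1.15 log units; beyond the scatter) and a 36-fold lower number from compound 2 to compound 4 (1.55 log units; beyond the scatter) and also a 5.4-fold lower number from compound 1 to compound 4 (0.73 log units; beyond the scatter), so compound 4 is the strongest of the four. Leaving the nitrile behind therefore does not by itself raise the number; what the 5-methylpyridin-2-yl group brings outweighs it. Nothing measured here accounts for this gain.

On these data alone, the ring nitrogen and the methyl group enter together, so their separate shares stay open. A plain pyridin-2-yl group or a 4-methylphenyl group would begin to divide them.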